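The source may report more compounds than this note shows. Statements on the series, on what has been measured and on what is new or still open speak of the compounds shown alone.

In a functional assay on L02 cells (Homo sapiens) for inhibition, read by Griess assay, with stated times of 1 h and 24 h (on this read-out lower numbers stand for stronger inhibition and higher numbers for weaker inhibition), three compounds share one core and differ in the group on a nitrogen on an aromatic ring. Compound 1 `COc1cc(/C=C/c2nc(Nc3ccc(C)cc3)c3sccc3n2)cc(OC)c1OC` gives only a limit, < 40000 nM. Compound 2 `COc1ccc(CNc2nc(/C=C/c3cc(OC)c(OC)c(OC)c3)nc3ccsc23)cc1` also gives only a limit, > 1000000 nM. Among the compounds with values here, compound 3 `COc1cc(/C=C/c2nc(NCc3ccco3)c3sccc3n2)cc(OC)c1OC` gives the only actual number, 189000 nM, and two steps place it: an at least 4.7-fold higher number from compound 1 to compound 3 (0.67 log units; beyond the scatter) and an at least 5.2-fold lower number from compound 2 to compound 3 (0.72 log units; beyond the scatter). Compound 4 `COc1cc(/C=C/c2nc(NC(C)C)c3sccc3n2)cc(OC)c1OC` has isopropyl in place of (furan-2-yl)methyl on a nitrogen on an aromatic ring. These steps and an at least 25-fold higher number from compound 1 to compound 2 (1.39 log units; beyond the scatter) all lie beyond the scatter, yet in each of them the entering group keeps a ring, so none shows the direction for this change. The expected change is small, a 1.3-fold higher number from compound 3 to compound 4 (0.12 log units; within the scatter), with its direction uncertain. Compound 4 is expected at 250000 nM, with an estimated range from 60000 nM to 1000000 nM.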

Compound 4, half-maximal inhibitory concentration: > 1000000 nM
Compound 4 gave a limit, no number (the forecaster's own chance of this, stated with the estimate: 25%); middle value at least 4.0-fold (0.60 log units) from the limit.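

In this assay, within the data shown here, isopropyl is the only entering group here without a ring, and it gives an at least 5.2-fold higher number from compound 3 to compound 4 (0.72 log units; beyond the scatter) and an at least 25-fold higher number from compound 1 to compound 4 (1.39 log units; beyond the scatter). A ring alone does not decide the outcome, as compound 2, which keeps one in 4-methoxybenzyl, is also only a limit. The step between compound 2 and compound 4 cannot be read, because both stand at the same limit: the limit of > 1000000 nM in this assay, at which 2 of the 4 values shown sit.

From the compounds shown here alone, it remains open whether the aromatic ring matters, as cyclohexylmethyl on this nitrogen would test, and how an open chain longer than isopropyl, such as n-butyl, would read.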